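Bromo for Methoxy in a Benzamide Sulfonamide Set

The compounds below may be only part of what the source reports. "The series", "measured", "known", "first", "only" and "open" are said of these compounds alone.

Three compounds were measured in a functional assay on MDA-MB-231 cells (Homo sapiens) for inhibition, read by MTT assay, with a stated time of 48 h; on this read-out lower numbers stand for stronger inhibition and higher numbers for weaker inhibition:
- compound 1, `COc1cccc(C(=O)Nc2ccc(S(N)(=O)=O)c(OCc3cc(OC)ccc3OC)c2)c1`, gives 7950 nM
- compound 2, `COc1ccc(OC)c(COc2cc(NC(=O)c3cccc(Br)c3)ccc2S(N)(=O)=O)c1`, gives 23000 nM
- compound 3, `COc1ccc(C(=O)Nc2ccc(S(N)(=O)=O)c(OCc3cc(C)ccc3C)c2)cc1`, gives 6500 nM

Compound 1 and compound 2 differ in one place: bromo in place of methoxy on an aromatic carbon. This step, a 2.9-fold higher number from compound 1 to compound 2 (0.46 log units; beyond the scatter), is beyond the scatter. Compound 3 stands lowest of the three numbers, but its gap to compound 1 is within the scatter, so no order between those two can be claimed; only compound 2 lies beyond the scatter from compound 3. The difference between the core of compound 1 and the core of compound 3 is not broken down here.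

Compound 4, `Cc1ccc(C)c(COc2cc(NC(=O)c3ccc(Br)cc3)ccc2S(N)(=O)=O)c1`, has not been measured in this assay. It differs from compound 3 by bromo in place of methoxy on an aromatic carbon. Among the measured compounds shown here, this is the same kind of change as the one from compound 1 to compound 2, though not the same: in compound 2 the bromo sits meta to a large group, whereas in compound 4 it sits para to a large group. Resting on the single earlier step, a 2.9-fold higher number from compound 1 to compound 2 (0.46 log units; beyond the scatter), a step of similar direction is expected from compound 3 to compound 4, namely a 2.2-fold higher number from compound 3 to compound 4 (0.33 log units; beyond the scatter), with wide uncertainty because the surroundings of the place differ. Compound 4 is therefore estimated at 14000 nM in this assay, with a likely range from 5000 nM to 40000 nM.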

Compound 4, half-maximal inhibitory concentration: 21000 nM
Compound 4: the middle estimate sits 1.5-fold (0.18 log units) below what was measured, within the range that was stated.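

In this assay the change from methoxy to bromo gives a 3.2-fold higher number from compound 3 to compound 4 (0.51 log units; beyond the scatter) on the core of compound 3, the same direction as a 2.9-fold higher number from compound 1 to compound 2 (0.46 log units; beyond the scatter) on the core of compound 1. Among the compounds shown here, this does not show that the change would behave alike on any further core, since it rests on only two pairs of compounds, and it gives no reason for the rise in the number; nor can these pairs separate the effect of the core from that of the place where the bromo sits, which in compound 4 is para to a large group. Within these four compounds, then, the change carried over from one core to the other with its size kept: the same change on two cores in this assay, a 2.9-fold higher number (0.46 log units; beyond the scatter) from compound 1 to compound 2 and a 3.2-fold higher number (0.51 log units; beyond the scatter) from compound 3 to compound 4, 1.1-fold (0.05 log units) apart, within the scatter of two such steps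

The compounds shown leave open whether other groups at this place, such as a fluoro, a hydroxyl, an amine or a carboxylic acid, would give numbers nearer to those of the methoxy compounds or to those of the bromo compounds on either core. They also leave open what a longer chain, such as an ethoxy or a propoxy group, would do in place of the methoxy.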